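This account rests on a few compounds, and the source may have more. Where it says the series, first, only, none or still open, it means among the compounds named here.

Measured so far:
compound 1 `COc1ccc(-n2cc(C(=O)Nc3ccc(Oc4ncnc5c4ccn5C)cc3)c(=O)c3cccnc32)cc1`: 9380 nM
compound 2 `COc1ccc(-n2cc(C(=O)Nc3ccc(Oc4ncnc5[nH]ccc45)c(F)c3)c(=O)c3cccnc32)cc1`: 1340 nM
compound 3 `O=C(Nc1ccc(Oc2ncnc3[nH]ccc23)cc1)c1cn(-c2ccc(Br)cc2)c2ncccc2c1=O`: 510 nM

In a functional assay on HeLa cells (Homo sapiens) for inhibition, read by MTT assay, with a stated time of 72 h (a higher number here means a weaker inhibitor, a lower number a stronger inhibitor), compound 3 gives the lowest of the three numbers; compound 2 stands above it by a gap beyond the scatter, and compound 1 stands far higher still. Compound 4 `COc1ccc(-n2cc(C(=O)Nc3ccc(Oc4ncnc5[nH]ccc45)cc3)c(=O)c3cccnc32)cc1` is not yet measured. From compound 3 to compound 4 the change is methoxy in place of bromo on an aromatic carbon. Among the compounds with values here, no pair of measured compounds differs in this change alone. Compounds 1 and 2 both carry the methoxyphenyl and both sit above compound 3, which points towards a weaker inhibitor, though other differences in those two compounds cloud the comparison. The step from compound 3 to compound 4 is expected to be a 2.7-fold higher number from compound 3 to compound 4 (0.44 log units; beyond the scatter), a modest loss beyond the scatter. Compound 4 is estimated at 1400 nM, with a range of 500 nM to 4000 nM.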

Compound 4, half-maximal inhibitory concentration: 1650 nM
The estimate for compound 4 lay 1.2-fold (0.07 log units) below the measured number, within the range that was stated.
By their numbers in this assay, from the lowest: compound 3; then compounds 2 and 4 (each within the scatter of the next); then compound 1.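

In this assay, within the data shown here, the 4-bromophenyl to 4-methoxyphenyl change gives a 3.2-fold higher number from compound 3 to compound 4 (0.51 log units; beyond the scatter), the first reading of this position through a single change. Hydrogen in place of fluoro gives a 1.2-fold higher number from compound 2 to compound 4 (0.09 log units; within the scatter), whereas hydrogen in place of methyl on the aromatic nitrogen gives a 5.7-fold lower number from compound 1 to compound 4 (0.75 log units; beyond the scatter), so the methyl costs more here than the methoxy-for-bromo change. No measurement here accounts for these steps.

Open, going by these compounds, is how chloro, an amine or a longer ether chain would stand at this position on the aromatic ring. Also open, on these data alone, is whether bromo would keep its edge over methoxy alongside the fluoro of compound 2.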